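Swapping the Piperidine Ester for a Thiazolidinedione Ring

A few compounds are considered here, and "the series" means these few. Any claim that something is new, unique, unknown or untested is made for them only; others in the source may bear on it.

Compound 2 `COC(=O)CC1CCN(C[C@H]2CN(c3ccc(-n4cc(-c5ccccn5)cn4)c(F)c3)C(=O)O2)CC1` carries a 4-((methoxycarbonyl)methyl)piperidin-1-yl group on a saturated chain carbon bound to a saturated ring carbon. Among the compounds with values here, in a physicochemical assay for lipophilicity, read by HPLC, measured as octanol-water partition (on this read-out higher numbers stand for higher lipophilicity and lower numbers for lower lipophilicity), compound 2 gives 1.78, the lower of the two numbers known here; its only neighbour, compound 1 `CN1CCN(C[C@H]2CN(c3ccc(-n4cc(-c5ccccn5)cn4)c(F)c3)C(=O)O2)CC1`, gives 2.2 in this assay, and the change at this place reads a number 0.42 log units lower from compound 1 to compound 2 (beyond the scatter).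

Compound 3 `O=C1CSC(=O)N1C[C@H]1CN(c2ccc(-n3cc(-c4ccccn4)cn3)c(F)c2)C(=O)O1` differs from compound 2 only at that same place: 2,4-dioxo-1,3-thiazolidin-3-yl in place of 4-((methoxycarbonyl)methyl)piperidin-1-yl on a saturated chain carbon bound to a saturated ring carbon. Within the data shown here, the one measured step that bears on this exchange is the one from compound 1 to compound 2, where replacing the group on this chain carbon moved this assay by a modest amount beyond the scatter. A second exchange of the group at the same place is therefore expected to move the number by a similar, modest amount, most likely downward, though a result within the scatter would not be surprising.

Compound 3 is thus estimated at 1.55 in this assay, within a range of 0.95 to 2.15, which corresponds to an expected step of a number 0.23 log units lower from compound 2 to compound 3 (within the scatter).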

Compound 3, partition coefficient: 2.18
Beside the measured number, compound 3's estimate is 0.63 log units below it; the measured number lies above the stated range.
By their numbers in this assay, from the lowest: compound 2; then compounds 3 and 1 (each within the scatter of the next).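

This result shows that the direction of the earlier step does not hold for every exchange at this place: in this assay, the move to the 2,4-dioxo-1,3-thiazolidin-3-yl group gives a number 0.40 log units higher from compound 2 to compound 3 (beyond the scatter). Compared with the 4-methylpiperazin-1-yl group, the same group gives a number 0.02 log units lower from compound 1 to compound 3 (within the scatter), so among these three compounds only the 4-((methoxycarbonyl)methyl)piperidin-1-yl group stands apart, even though the 2,4-dioxo-1,3-thiazolidin-3-yl group brings a five-membered non-aromatic ring with sulfur to this saturated chain carbon. No measured information explains why the three groups fall where they do.

The 4-((methoxycarbonyl)methyl)piperidin-1-yl and 2,4-dioxo-1,3-thiazolidin-3-yl groups differ at once in ring size, atom count, hetero atoms and double bonds, so these compounds cannot show which of those differences goes with the step. From the compounds shown here alone, it remains open where a 4-(carboxymethyl)piperidin-1-yl group, with a carboxylic acid in place of the methyl ester, or a plain piperidin-1-yl group without the side chain would fall relative to compound 2 and compound 1.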